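The compounds below may be only part of what the source reports. "The series", "measured", "known", "first", "only" and "open" are said of these compounds alone.

Two compounds have been measured so far:
compound 1, `CN(C(=O)C(C)(C)C)c1ccc2[nH]c(-c3n[nH]c4ccccc34)cc2n1`, giving 24400 nM
compound 2, `CN(C(=O)CCc1ccccc1)c1ccc2[nH]c(-c3n[nH]c4ccccc34)cc2n1`, giving 18100 nM

Both numbers come from a functional assay on A549 cells (Homo sapiens) for antiproliferative activity, read by MTT assay, with a stated time of 72 h (a lower number here means a stronger inhibitor, a higher number a weaker inhibitor), a measure of how strongly each compound slows the growth of lung cancer cells. Among the measured compounds shown here, compound 2 gives the lowest of the two numbers, but its only neighbour, compound 1, sits just a 1.3-fold lower number from compound 1 to compound 2 (0.13 log units; within the scatter) away, so the two cannot be told apart on these figures alone.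

Compound 3, `CN(C(=O)c1ccc(Cl)cc1)c1ccc2[nH]c(-c3n[nH]c4ccccc34)cc2n1`, is the next candidate. It differs from compound 2 in one place: 4-chlorophenyl in place of phenethyl on a carbonyl carbon. For the measured compounds named here, the only measured step that touches this same position is the one from compound 1 to compound 2, where tert-butyl gave way to phenethyl and the number barely moved. That single step says the group on the carbonyl carbon has so far made little difference, yet it says nothing about an aromatic ring attached directly to that carbon. The expectation is therefore a step of a 1.2-fold lower number from compound 2 to compound 3 (0.08 log units; within the scatter), not clearly beyond the scatter. Compound 3 is accordingly estimated at 15000 nM, with a range from 5000 nM to 45000 nM.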

Compound 3, half-maximal inhibitory concentration: 2220 nM
Compound 3: middle estimate off by 6.8-fold (0.83 log units), on the high side; the measured number lies below the stated range.
By their numbers in this assay, from the lowest: compound 3; then compounds 2 and 1 (each within the scatter of the next).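

The group on this carbonyl carbon can matter after all in this assay: 4-chlorophenyl in place of phenethyl gives an 8.2-fold lower number from compound 2 to compound 3 (0.91 log units; beyond the scatter), and 4-chlorophenyl in place of tert-butyl gives an 11-fold lower number from compound 1 to compound 3 (1.04 log units; beyond the scatter), whereas the earlier swap of tert-butyl for phenethyl stayed within the scatter. Phenethyl also carries a six-membered aromatic ring of carbon only, so compound 2 shows that having such a ring somewhere in the group does not by itself go with the lower number seen for compound 3. No measurement is available to explain why 4-chlorophenyl stands apart from the other two groups.

The step from phenethyl to 4-chlorophenyl removes the carbon chain that holds the ring and adds a chlorine in a single change, so these compounds cannot show which of the two differences accounts for the lower number. On these data alone, a plain phenyl group would separate those two differences, while 4-fluorophenyl or 4-methoxyphenyl would test whether chlorine itself is needed, and all of these remain open here.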